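Pyridin-2-yl for Thiophen-2-yl in an Inactive Pair

The compounds below may be only part of what the source reports. "The series", "measured", "known", "first", "only" and "open" are said of these compounds alone.

Compound 1, `CCOC(=O)C12C(=O)OCC=C1COC2c1ccco1`: in a functional assay on QGY cells (Homo sapiens) for cytotoxicity, read by MTT assay (a higher number here means a weaker inhibitor, a lower number a stronger inhibitor), compound 1 reaches only the assay limit > 1000000 nM.
Compound 2, `CCOC(=O)C12C(=O)OCC=C1COC2c1cccs1`: in this assay compound 2 likewise reaches only the assay limit > 1000000 nM.

Within the data shown here, compound 2 therefore stands at a limit rather than at a number, and the one measured step, a step that the two limits leave unreadable from compound 1 to compound 2, cannot be sized, since both of its ends are limits. The whole of the evidence so far is summed up by the limit of > 1000000 nM in this assay, at which 2 of the 2 values shown sit.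

Compound 3, `CCOC(=O)C12C(=O)OCC=C1COC2c1ccccn1`, is the next member. Its change from compound 2 is pyridin-2-yl in place of thiophen-2-yl on a saturated ring carbon. Among the measured compounds shown here, the only measured step that bears on it is the one from compound 1 to compound 2, which swapped one five-membered heteroaromatic ring for another on the same saturated ring carbon without moving either compound off the limit. For the measured compounds named here, no step of readable size exists in this set, so no direction can be drawn from it. The expectation for compound 3 is accordingly that it too will sit at or near the limit, with an estimated step that the limit leaves unreadable from compound 2 to compound 3 meaning no change beyond the scatter. Compound 3 is estimated at 2000000 nM, within a range from 500000 nM to 10000000 nM.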

Compound 3, half-maximal inhibitory concentration: > 1000000 nM
Compound 3: no number, only a limit (the forecaster's own chance of this, stated with the estimate: 85%); the middle value does not contradict the limit.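

Compound 3, like compound 1 and compound 2, gives only a limit in this assay, so the steps among these three compounds cannot be read. The compounds shown leave open whether any change to the shared core would give a number rather than a limit, and the evidence stops at this: the limit of > 1000000 nM in this assay, at which 3 of the 3 values shown sit.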